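A long-chain quinone traded from imidazole to trihydroxyphenoxy

This account rests on a few compounds, and the source may have more. Where it says the series, first, only, none or still open, it means among the compounds named here.

Compound 1, `COC1=C(OC)C(=O)C(CCCOCc2cccc(S(=O)(=O)O)c2)=C(C)C1=O`, in a functional assay on HL-60 cells (Homo sapiens) for antiproliferative activity, read by MTT assay, with a stated time of 48 h (a higher number here means a weaker inhibitor, a lower number a stronger inhibitor), gives > 200000 nM, which is a limit of the assay and not a number.
Compound 2, `COC1=C(OC)C(=O)C(CCCCCCCCCCn2ccnc2)=C(C)C1=O`, in this assay gives 3000 nM.
Compound 3, `COC1=C(OC)C(=O)C(CCCO)=C(C)C1=O`, in this assay gives 13000 nM.

Among the numbers shown, compound 2 stands lowest. The nearest number belongs to compound 3, and the gap between them is beyond the usual scatter, so compound 2 is the stronger inhibitor of that pair. Compound 1 sits at the limit of > 200000 nM in this assay, at which 1 of the 3 values shown sits, and this says only that the assay reached its limit there.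

Compound 4, `COC1=C(OC)C(=O)C(CCCCCCCCCCOc2c(O)cc(O)cc2O)=C(C)C1=O`, has not been measured. It differs from compound 2 in one place: 2,4,6-trihydroxyphenoxy in place of 1H-imidazol-1-yl on a saturated chain carbon, ten or more bonds along the chain from a double-bonded ring carbon. For the measured compounds named here, no pair of measured compounds differs in a single place, so nothing measured here bears directly on the size of this change. The long saturated chain of compound 2 is kept, and only its end group is exchanged.

Compound 4 is expected to give about 5000 nM, within a range from 1500 nM to 20000 nM. The step that this estimate means, a 1.7-fold higher number from compound 2 to compound 4 (0.22 log units; within the scatter), is expected to be modest and toward a weaker inhibitor, possibly not beyond the scatter.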

Compound 4, half-maximal inhibitory concentration: > 200000 nM
Compound 4 was reported as a limit; the forecaster's own chance of this, stated with the estimate: 10%; middle value at least 40-fold (1.60 log units) away from the limit.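

In this assay, for the compounds shown here, the end group of the long saturated chain proves decisive: replacing 1H-imidazol-1-yl with 2,4,6-trihydroxyphenoxy gives an at least 66-fold higher number from compound 2 to compound 4 (1.82 log units; beyond the scatter), the first single-place change in this set and a large one. The long saturated chain and the shared core do not alone secure the number seen for compound 2, as compound 4 keeps both and still loses the measurable inhibition. Compound 4 gives > 200000 nM, which is a limit of the assay and not a number, and it shares that limit with one other compound shown: the limit of > 200000 nM in this assay, at which 2 of the 4 values shown sit.

Going by these compounds alone, with only two end groups on the long chain, it remains open whether 1H-imidazol-1-yl improves inhibition or 2,4,6-trihydroxyphenoxy abolishes it, and an amine or a carboxylic acid at the same chain end would help separate these possibilities. No pair shown isolates chain length from end group either, so the effect of a longer chain with either end group remains unanswered.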